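Dichlorophenyl exchange from compound 2 to compound 3

A few compounds are considered here, and "the series" means these few. Any claim that something is new, unique, unknown or untested is made for them only; others in the source may bear on it.

- compound 1 `COc1cccc(/C=C2\CCC/C(=C\c3cccc(Br)c3)C2=O)c1OC`: 23900 nM
- compound 2 `COc1cccc(/C=C2\CCC/C(=C\c3cccc(Cl)c3Cl)C2=O)c1OC`: > 50000 nM (a limit, not a number)

In an ADME assay on NHDF cells (Homo sapiens) for cytotoxicity, read by MTT assay, with a stated time of 72 h (on this read-out lower numbers stand for stronger inhibition and higher numbers for weaker inhibition), compound 1 gives a measured number (23900 nM). Compound 2 stands only at a limit of the assay (> 50000 nM).

Compound 3 `COc1cccc(/C=C2\CCC/C(=C\c3ccc(Cl)cc3Cl)C2=O)c1OC` carries 2,4-dichlorophenyl in place of 2,3-dichlorophenyl on a double-bonded chain carbon bound to a double-bonded ring carbon.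

Going by the values given here, one measured step bears on this (an at least 2.0-fold higher number from compound 1 to compound 2 (0.32 log units; beyond the scatter)). Among the compounds with values here, it exchanges a different group, and no measured step exchanges one dichlorophenyl for another, so it is only a loose guide to size. In this assay a step of no greater size is expected, towards a lower number if there is any change. The expected step is small (an at least 1.2-fold lower number from compound 2 to compound 3 (0.09 log units; that floor lies within the scatter)). For compound 3 the estimated value is 40000 nM (expected range 18000 nM to 90000 nM).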

Compound 3, half-maximal inhibitory concentration: 49200 nM
The estimate for compound 3 lay 1.2-fold (0.09 log units) below the measured number, and the stated range covers the measured number.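

In this assay, a dichlorophenyl group at this place now has a measured size against 3-bromophenyl (a 2.1-fold higher number from compound 1 to compound 3 (0.31 log units; beyond the scatter)), and with compound 2 also standing higher than compound 1, the higher number holds for both dichlorophenyl groups shown. Exchanging 2,3-dichlorophenyl for 2,4-dichlorophenyl sets no order between the two (an at least 1.0-fold lower number from compound 2 to compound 3 (0.00 log units; that floor lies within the scatter)). Compound 2 is held only at a limit and not at a number, which caps what this exchange can show: the limit of > 50000 nM in this assay, at which 1 of the 3 values shown sits.

On these data alone, whether a single chlorine, as in 3-chlorophenyl, would give a number closer to that of compound 1 stays open. Also open is how an amine or a carboxylic acid on this phenyl ring would behave, as the compounds shown carry only halogens there.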